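A few compounds are considered here, and "the series" means these few. Any claim that something is new, unique, unknown or untested is made for them only; others in the source may bear on it.

In a functional assay on K562 cells (Homo sapiens) for cytotoxicity, read by trypan blue exclusion, with a stated time of 96 h (a lower number here means a stronger inhibitor, a higher number a weaker inhibitor), compound 1 `COc1cc(OC)c(/C=C/S(=O)(=O)Nc2ccc(F)c(N)c2)c(OC)c1` gives 5000 nM, and compound 2 `COc1cc(OC)c(/C=C/S(=O)(=O)Nc2ccc(OC)c(N)c2)c(OC)c1` gives 3 nM, the lower of the two numbers. Within the data shown here, the only measured step, a 1700-fold lower number from compound 1 to compound 2 (3.22 log units; beyond the scatter), is large and comes from methoxy in place of fluoro on an aromatic carbon. Compound 3 `COc1cc(OC)c(/C=C/S(=O)(=O)Nc2ccc(OC)c(NCC(=O)O)c2)c(OC)c1` instead has carboxymethyl in place of hydrogen on a nitrogen on an aromatic ring. Among the measured compounds shown here, that measured step concerns a different place, so it shows only that one change can move the number greatly, and it gives no direct guide here. With compound 2 at 3 nM, a moderate rise seems the likelier outcome. The expected change is a 10-fold higher number from compound 2 to compound 3 (1.00 log units; beyond the scatter). Compound 3 is estimated at 30 nM, within an expected range of 6 nM to 300 nM.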

Compound 3, half-maximal inhibitory concentration: 20 nM
The estimate for compound 3 lay 1.5-fold (0.18 log units) above the measured number; the range from low to high includes it.
By their numbers in this assay, from the lowest: compound 2; then compound 3; then compound 1.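

This is the first change shown at the nitrogen on the aromatic ring, and it shows that this nitrogen can carry carboxymethyl with only a partial loss of strength in this assay: a 6.7-fold higher number from compound 2 to compound 3 (0.82 log units; beyond the scatter). That modest step is far smaller than the large step at the other place, a 1700-fold lower number from compound 1 to compound 2 (3.22 log units; beyond the scatter). Nothing available explains the rise in the number.

Going by these compounds, whether the rise comes from the carboxylic acid end or from the added chain itself stays open. A methyl group, a methyl ester or a longer chain ending in a carboxylic acid on the same nitrogen could separate the two.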